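Methoxy to Chloro on a Nicotinic Receptor Ligand

The source may report more compounds than this note shows. Statements on the series, on what has been measured and on what is new or still open speak of the compounds shown alone.

Among the compounds with values here, compound 2 `COc1ccc(/C=C2\CCCN=C2c2cccnc2)cc1` gives 490 nM in an assay on membranes from brain for displacement of a labelled ligand from Neuronal acetylcholine receptor; alpha4/beta2 (Rattus norvegicus), with a stated time of 3 h (a higher number here means a weaker inhibitor, a lower number a stronger inhibitor), the lowest of the two numbers so far, though only by a margin within the scatter. Its nearest neighbour is compound 1 `C(=C1\CCCN=C1c1cccnc1)\c1ccccc1`, which in this assay gives 850 nM; the step of a 1.7-fold lower number from compound 1 to compound 2 (0.24 log units; within the scatter) lies within the scatter, so the two cannot be ordered.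

Compound 3 `Clc1ccc(/C=C2\CCCN=C2c2cccnc2)cc1` is not yet measured. It differs from compound 2 by chloro in place of methoxy on an aromatic carbon. Within the data shown here, only one measured step bears on this position, a 1.7-fold lower number from compound 1 to compound 2 (0.24 log units; within the scatter), and it was within the scatter. Among the measured compounds shown here, nothing measured speaks to a chloro group at this place, so the only guide is that a change here has so far moved the number little. One therefore expects no step beyond the scatter in this assay. For compound 3 the expected step is a 1.0-fold higher number from compound 2 to compound 3 (0.01 log units; within the scatter). Compound 3 is estimated at 500 nM, with a range from 150 nM to 1600 nM.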

Compound 3, inhibition constant: 970 nM
Beside the measured number, compound 3's estimate is 1.9-fold (0.29 log units) below it; the range from low to high includes it.
By their numbers in this assay, from the lowest: compounds 2, 1 and 3 (each within the scatter of the next).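

Chloro in place of methoxy on an aromatic carbon, para to a large group, gives a 2.0-fold higher number from compound 2 to compound 3 (0.30 log units; within the scatter) in this assay, so this second change at the position also stays within the scatter. Chloro in place of hydrogen at the same place gives a 1.1-fold higher number from compound 1 to compound 3 (0.06 log units; within the scatter), which shows that a halogen, like methoxy, leaves the number within the scatter of the compound with hydrogen there, and hydrogen, methoxy and chloro therefore cannot be told apart by pairwise steps at this position. No measurement shown here offers an explanation for these numbers.

What the compounds shown leave open is whether an amine, a carboxylic acid or a longer chain at this place would produce a step beyond the scatter. They also leave open whether the same holds for a hydroxyl or a nitrile group there.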